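The source may hold more compounds than are shown below. What is called first, only, known or untested is meant among the compounds shown, and "the series" means these compounds.

Compound 1 `COc1cccc(CNCCCNc2ccnc3cc(-c4ccc(C(C)(C)C)cc4)ccc23)c1O` is one of three compounds whose permeability has been read in an ADME assay for permeability, using PAMPA, with a stated time of 30 min, at pH 7.4; on this read-out higher numbers stand for higher permeability and lower numbers for lower permeability; in that assay compound 1 gives 237 10^-6 cm/s. Compound 2 `CC(C)(C)c1ccc(-c2ccc3c(NCCCNCc4ccco4)ccnc3c2)cc1` gives 237 10^-6 cm/s, and compound 3 `COc1ccc(-c2ccc3c(NCCCNCc4ccco4)ccnc3c2)cc1` gives 237 10^-6 cm/s, so compound 1 sits level with both at the digits shown, neither ahead nor behind. The step of no change at the digits printed from compound 1 to compound 2 (within the scatter) came with furan-2-yl in place of 2-hydroxy-3-methoxyphenyl on a saturated chain carbon bound to an amine nitrogen, and the step of no change at the digits printed from compound 2 to compound 3 (within the scatter) came with methoxy in place of tert-butyl on an aromatic carbon; neither moved the read-out beyond the scatter.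

Compound 4 `COc1cccc(CNCCCNc2ccnc3cc(Oc4ccc(F)cc4)ccc23)c1O` has not yet been measured. It differs from compound 1 in a single place: 4-fluorophenoxy in place of 4-(tert-butyl)phenyl on an aromatic carbon. Going by the values given here, the closest measured comparison is the step from compound 2 to compound 3, where tert-butyl on an aromatic carbon gave way to methoxy with no change in this assay; the present change likewise removes a tert-butyl group from the shared core, though it brings in 4-fluorophenoxy, for which no measured step exists. With every change so far leaving this assay untouched, the expected step is a 1.1-fold lower number from compound 1 to compound 4 (0.03 log units; within the scatter), that is, no movement beyond the scatter. Compound 4 is therefore estimated at 220 10^-6 cm/s, with a range from 110 10^-6 cm/s to 330 10^-6 cm/s.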

Compound 4, apparent permeability: 317 10^-6 cm/s
Estimate against measurement, compound 4: 1.4-fold (0.16 log units) below, and the stated range covers the measured number.
By their numbers in this assay, from the lowest: compounds 1, 2, 3 and 4 (each within the scatter of the next).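

In this assay, putting 4-fluorophenoxy in place of 4-(tert-butyl)phenyl on this aromatic carbon gives a 1.3-fold higher number from compound 1 to compound 4 (0.13 log units; within the scatter), so the read-out stays within the scatter even when the whole group on the shared core is exchanged. The earlier step at this end of the molecule, no change at the digits printed from compound 2 to compound 3 (within the scatter), altered only the tert-butyl group and kept the phenyl ring attached to the core, whereas here the entering group is smaller by heavy-atom count, contains oxygen and fluorine, and carries a hydrogen-bond acceptor that 4-(tert-butyl)phenyl lacks; none of these differences is accompanied by a change beyond the scatter in these two compounds. No measurement shown here explains why the read-out holds across this change.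

All four compounds lie within the scatter of one another, so the compounds shown do not reveal what kind of group on this aromatic carbon, if any, would shift the read-out beyond the scatter. From the compounds shown here alone, a carboxylic acid or an amine at this place would test that, and it also remains open whether 4-fluorophenoxy gives the same result alongside the furan-2-yl group of compounds 2 and 3.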